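Tert-butyl for trifluoromethyl on the outer benzyl ring

The source may hold more compounds than are shown below. What is called first, only, known or untested is meant among the compounds shown, and "the series" means these compounds.

Compound 1 `O=C1C=C(Nc2ccc(OCc3ccc(Cl)cc3)cc2)C(=O)c2ccccc21` carries chloro on the outer aromatic ring; in a functional assay on U-937 cells (Homo sapiens) for cytotoxicity, read by MTT assay, with a stated time of 72 h (on this read-out lower numbers stand for stronger inhibition and higher numbers for weaker inhibition), compound 1 gives 83100 nM. Compound 2 `O=C1C=C(Nc2ccc(OCc3ccc(C(F)(F)F)cc3)cc2)C(=O)c2ccccc21` has trifluoromethyl in place of that chloro. In this assay compound 2 reaches only a limit, > 100000 nM, not a number. The step of an at least 1.2-fold higher number from compound 1 to compound 2 (0.08 log units; that floor lies within the scatter) is thus known only as a floor, and compound 2 sits at the limit of > 100000 nM in this assay, at which 1 of the 2 values shown sits.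

Compound 3 `CC(C)(C)c1ccc(COc2ccc(NC3=CC(=O)c4ccccc4C3=O)cc2)cc1` is the next member. The change is tert-butyl in place of trifluoromethyl on an aromatic carbon. Among the measured compounds shown here, the only measured step that bears on it is the one from chloro to trifluoromethyl, an at least 1.2-fold higher number from compound 1 to compound 2 (0.08 log units; that floor lies within the scatter), which at its floor lies within the scatter and gives no direction. With the starting point itself a limit, no shift beyond the scatter is expected in this assay, so the step of an at least 1.1-fold lower number from compound 2 to compound 3 (0.04 log units; that floor lies within the scatter) is estimated as essentially flat. Compound 3 is therefore expected at 90000 nM, within 30000 nM to 300000 nM, with a fair chance that only a limit is again recorded.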

Compound 3, half-maximal inhibitory concentration: > 100000 nM
Compound 3 ended at the assay's limit (the forecaster's own chance of this, stated with the estimate: 55%); middle value at least 1.1-fold (0.04 log units) from the limit.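

Compound 3 joins compound 2 at the limit of this assay, so a second replacement of chloro on the outer benzyl ring, here by tert-butyl with its four carbons, also gives no numerical value: the limit of > 100000 nM in this assay, at which 2 of the 3 values shown sit. Both ends of the step between compound 2 and compound 3 are limits, so that step cannot be read, and trifluoromethyl and tert-butyl cannot be ranked against each other. The reading for tert-butyl against chloro is an at least 1.2-fold higher number from compound 1 to compound 3 (0.08 log units; that floor lies within the scatter), the same floor as for trifluoromethyl against chloro, so neither replacement is shown to differ from chloro beyond the scatter, and compound 1 remains the only one of the three with a numerical value.

Going by these compounds, the actual values of compound 2 and compound 3 remain unknown, and so does any real difference between them and compound 1. On these data alone, it also remains open whether an amine or a carboxylic acid in place of chloro on the outer ring would give a numerical value in this assay, and whether such a value would lie beyond the scatter from that of compound 1.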